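Aminopyrazinyl in place of methoxypyridinyl: compound 3

A few compounds are considered here, and "the series" means these few. Any claim that something is new, unique, unknown or untested is made for them only; others in the source may bear on it.

Among the compounds with values here, compound 1 `COc1ccnc(-c2cc(Cl)ccc2NS(=O)(=O)c2ccc(C(C)(C)C)cc2)c1` is the weakest of the two measured members: in a functional assay on isolated protein for antagonist activity at C-C chemokine receptor type 9 (Homo sapiens), read by calcium flux, with a stated time of 10 min (a higher number here means a weaker inhibitor, a lower number a stronger inhibitor), compound 1 gives 2500 nM, the highest of the two numbers. Compound 2 `CNc1nccnc1-c1cc(Cl)ccc1NS(=O)(=O)c1ccc(C(C)(C)C)cc1` carries 3-(methylamino)pyrazin-2-yl in place of 4-methoxypyridin-2-yl, and in this assay compound 2 gives 25 nM; the step is a 100-fold lower number from compound 1 to compound 2 (2.00 log units; beyond the scatter).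

Compound 3 `CCNc1nccnc1-c1cc(Cl)ccc1NS(=O)(=O)c1ccc(C(C)(C)C)cc1` is not yet measured. Relative to compound 1 the change is a group of 9 heavy atoms (6 carbon, 3 nitrogen; one six-membered aromatic ring with 2 hetero atoms) in place of a group of 8 heavy atoms (6 carbon, 1 nitrogen, 1 oxygen; one six-membered aromatic ring with 1 hetero atom), on an aromatic carbon. Within the data shown here, the entering group is a close relative of the 3-(methylamino)pyrazin-2-yl group of compound 2, so the only measured step that bears on it is the one from compound 1 to compound 2, which was large, a 100-fold lower number from compound 1 to compound 2 (2.00 log units; beyond the scatter). A step in the same direction is therefore expected in this assay, lowering the number strongly; whether the change gives exactly the same size as in compound 2 cannot be settled from two compounds. The step expected from the estimate is a 63-fold lower number from compound 1 to compound 3 (1.80 log units; beyond the scatter). Compound 3 is estimated at 40 nM, with a range from 10 nM to 160 nM.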

Compound 3, half-maximal inhibitory concentration: 421 nM
The estimate for compound 3 lay 11-fold (1.02 log units) below the measured number, outside the stated range (above it).
By their numbers in this assay, from the lowest: compound 2; then compound 3; then compound 1.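

In this assay, the advantage of the entering group over the 4-methoxypyridin-2-yl group of compound 1 persists only in part, with a 5.9-fold lower number from compound 1 to compound 3 (0.77 log units; beyond the scatter) as the step that remains. A single methyl in place of hydrogen on the saturated chain carbon bound to the nitrogen gives a 17-fold higher number from compound 2 to compound 3 (1.23 log units; beyond the scatter), so the large step seen earlier cannot be credited to the exchange of ring alone: at this position, the result also depends strongly on the chain carried by the amino nitrogen. Nothing available on these compounds accounts for this sensitivity to one added methyl.

The compounds shown leave open whether the trend between compound 2 and compound 3 extends in either direction, which a 3-aminopyrazin-2-yl group with a free amine and a longer chain such as propyl on the nitrogen would test. They also do not separate the contribution of the pyrazine ring from that of the amino nitrogen, a question that a 3-(methylamino)pyridin-2-yl group or a 3-methoxypyrazin-2-yl group could address.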